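Swapping the group on the oxygen of compound 2

The source may hold more compounds than are shown below. What is called first, only, known or untested is meant among the compounds shown, and "the series" means these compounds.

In a functional assay on BT-474 cells (Homo sapiens) for inhibition, read by CellTiter-Glo, with a stated time of 72 h (a higher number here means a weaker inhibitor, a lower number a stronger inhibitor), compound 1 (`Cc1cc(Nc2ncnc3cc(O)c(NC(=O)/C=C/[C@H]4CCCN4C)cc23)ccc1Oc1cnc2ccnn2c1`) gives 3.11 nM and compound 2 (`Cc1cc(Nc2ncnc3cc(O)c(NC(=O)/C=C/[C@H]4CCCN4C)cc23)ccc1Oc1cc2nccn2cn1`) gives 5.59 nM, so the two stand level within the scatter. Compound 3 (`Cc1cc(Nc2ncnc3cc(O)c(NC(=O)/C=C/[C@H]4CCCN4C)cc23)ccc1Oc1ccn2ccnc2c1`) keeps the shared core and changes only the group on an oxygen on an aromatic ring: a group of 9 heavy atoms (7 carbon, 2 nitrogen; one five-membered aromatic ring with 2 hetero atoms, one six-membered aromatic ring with 1 hetero atom) in place of a group of 9 heavy atoms (6 carbon, 3 nitrogen; one five-membered aromatic ring with 2 hetero atoms, one six-membered aromatic ring with 2 hetero atoms), on an oxygen on an aromatic ring. For the measured compounds named here, the only measured swap at this place, a 1.8-fold higher number from compound 1 to compound 2 (0.25 log units; within the scatter), stayed within the scatter, so no step beyond the scatter is expected in this assay. The expected step is a 1.2-fold lower number from compound 2 to compound 3 (0.09 log units; within the scatter). Compound 3 is estimated at 4.5 nM, with a range of 1.7 nM to 12 nM.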

Compound 3, half-maximal inhibitory concentration: 4.63 nM
Beside the measured number, compound 3's estimate is 1.0-fold (0.01 log units) below it; the range from low to high includes it.
By their numbers in this assay, from the lowest: compounds 1, 3 and 2 (each within the scatter of the next).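

Going from 3 hydrogen-bond acceptors to 2 in the group on the oxygen leaves the number in place (a 1.2-fold lower number from compound 2 to compound 3 (0.08 log units; within the scatter)). The comparison with the group of compound 1 reads the same way (a 1.5-fold higher number from compound 1 to compound 3 (0.17 log units; within the scatter)). So in this assay this position has now accepted three different groups, each with a five-membered and a six-membered aromatic ring, and all three stand level. No measurement at hand bears on this result.

As far as these compounds go, all three groups carry both rings, so it remains open whether a single phenyl ring or a morpholine on the oxygen would hold the number.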